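Swapping Hydroxy for Amino on a Sigma-1 Binder

This account rests on a few compounds, and the source may have more. Where it says the series, first, only, none or still open, it means among the compounds named here.

For the measured compounds named here, compound 1 `OC(CCCN1CCN(c2ncc(F)cn2)CC1)c1ccc(F)c2ccccc12` is the only compound here with a definite number: in an assay (Cavia porcellus) for displacement of a labelled ligand from Sigma non-opioid intracellular receptor 1 (Homo sapiens) (a lower number here means a stronger inhibitor, a higher number a weaker inhibitor), compound 1 gives 88 nM. Compound 2 `O=C(NC(CCCN1CCN(c2ncc(F)cn2)CC1)C1CCCCC1)c1ccc(F)cc1` was also tested. In this assay compound 2 reaches only a limit of the assay, > 2 nM, which is not a number. Compound 3 `NC(CCCN1CCN(c2ncc(F)cn2)CC1)c1ccc(F)c2ccccc12` keeps the core of compound 1 and differs by amino in place of hydroxy on a saturated chain carbon bound to an aromatic carbon and a saturated chain carbon. Going by the values given here, no measured step of this kind is known, so the expected step of a 1.5-fold lower number from compound 1 to compound 3 (0.17 log units; within the scatter) is modest, with either direction possible. Compound 3 is expected to give 60 nM in this assay, somewhere between 15 nM and 300 nM.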

Compound 3, half-maximal inhibitory concentration: 215 nM
Compound 3: middle estimate off by 3.6-fold (0.55 log units), on the low side; measured number inside the range.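

In this assay, amino in place of hydroxy on this saturated chain carbon gives a 2.4-fold higher number from compound 1 to compound 3 (0.39 log units; beyond the scatter), so this position does respond to the swap. The computed counts of heavy atoms, hydrogen-bond donors and hydrogen-bond acceptors match for the two groups, so those counts alone do not predict the change. Nothing measured here accounts for the shift.

With only amino and hydroxy compared at this carbon, no trend can be drawn. From the compounds shown here alone, how a methoxy group, a fluorine or a plain hydrogen at this carbon would compare remains open.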